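The compounds below may be only part of what the source reports. "The series", "measured", "known", "first", "only" and "open" are said of these compounds alone.

Compound 1 `O=c1c2cc(F)c(F)cc2ccn1[C@@H]1O[C@H](COP(=O)(O)OP(=O)(O)OP(=O)(O)O)[C@@H](O)[C@H]1O` serves as the starting point of this small series. In a functional assay for agonist activity at P2Y purinoceptor 2 (Homo sapiens), read by FLIPR (on this read-out lower numbers stand for an effect already at smaller amounts and higher numbers for an effect only at larger amounts of compound), compound 1 gives 16 nM. Compound 2 `CSc1cc2ccn([C@@H]3O[C@H](COP(=O)(O)OP(=O)(O)OP(=O)(O)O)[C@@H](O)[C@H]3O)c(=O)c2cc1F` keeps the shared core and the same triphosphate sugar, and in this assay compound 2 gives 3 nM. For the measured compounds named here, the one measured step, a 5.3-fold lower number from compound 1 to compound 2 (0.73 log units; beyond the scatter), shows that changing the substituent at this aromatic carbon can move the read-out beyond the scatter. Compound 2 therefore stands at the lowest of the two numbers shown; its nearest neighbour is compound 1 with the higher number.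

Compound 3 `CN(C)c1cc2ccn([C@@H]3O[C@H](COP(=O)(O)OP(=O)(O)OP(=O)(O)O)[C@@H](O)[C@H]3O)c(=O)c2cc1F` carries the change (dimethylamino in place of methylsulfanyl on an aromatic carbon). Going by the values given here, only the step from compound 1 to compound 2 touches this position, and it concerned a different group; no measured pair covers a dimethylamino group at all. That single step is of modest size, so the step from compound 2 to compound 3 is expected to stay within the scatter or to be modest in either direction, a 1.3-fold higher number from compound 2 to compound 3 (0.12 log units; within the scatter). Compound 3 is therefore estimated at 4 nM, within a range of 1.5 nM to 12 nM.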

Compound 3, half-maximal effective concentration: 4 nM
Compound 3: the middle estimate sits on the measured number at the digits printed, within the range that was stated.
By their numbers in this assay, from the lowest: compounds 2 and 3 (each within the scatter of the next); then compound 1.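

Read in this assay, the new compound shows that this aromatic carbon, ortho to a fluoro group, tolerates more than one replacement for fluoro: dimethylamino in place of methylsulfanyl gives a 1.3-fold higher number from compound 2 to compound 3 (0.12 log units; within the scatter), so exchanging a sulfur-linked group of 2 heavy atoms for a nitrogen-linked group of 3 heavy atoms leaves the read-out unchanged within the scatter. Dimethylamino in place of fluoro gives a 4.0-fold lower number from compound 1 to compound 3 (0.60 log units; beyond the scatter), which runs in the same direction as the earlier 5.3-fold lower number from compound 1 to compound 2 (0.73 log units; beyond the scatter), so both non-fluoro groups at this carbon sit beyond the scatter from compound 1, and neither of the two goes against that pattern. Nothing available on these groups accounts for this result.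

The compounds shown leave open whether the same holds for a primary amine, a methoxy group, a carboxylic acid or a longer chain such as ethylsulfanyl at this carbon. They also leave open how a replacement here would read with a hydrogen or a chloro group in place of the remaining fluoro group.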